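A few compounds are considered here, and "the series" means these few. Any claim that something is new, unique, unknown or untested is made for them only; others in the source may bear on it.

Measured so far in an in vitro functional assay on cells for agonist activity at Bombesin receptor subtype-3 (Mus musculus), read by luminescence and calcium flux; a lower number here means that less compound is needed, a higher number that more compound is needed for the effect:
- compound 1, `Cc1ccccc1Cc1cnc(CCc2ccc(-c3ccccc3C(=O)O)cc2)[nH]1`: 9.3 nM
- compound 2, `O=C(O)c1ccccc1-c1ccc(CCc2ncc(Cc3ccccc3F)[nH]2)cc1`: 9.5 nM
- compound 3, `CCC(C)(C)Cc1c[nH]c(CCc2ccc(-c3ccccc3C(=O)O)cc2)n1`: 9.6 nM

The three compounds share one core and differ only in the group carried on the saturated chain carbon bound to the aromatic carbon of that core. Compound 2 stands second of the three numbers, but all three lie within the scatter of one another: the step of a 1.0-fold higher number from compound 1 to compound 2 (0.01 log units; within the scatter) is within the scatter, and the values of compound 2 and compound 3 are likewise indistinguishable. Nothing here separates the three.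

Compound 4, `N#Cc1cccc(Cc2cnc(CCc3ccc(-c4ccccc4C(=O)O)cc3)[nH]2)c1`, has not been measured. It differs from compound 2 by 3-cyanophenyl in place of 2-fluorophenyl on a saturated chain carbon bound to an aromatic carbon. Going by the values given here, the only measured step at this position is a 1.0-fold higher number from compound 1 to compound 2 (0.01 log units; within the scatter), an exchange of one small aromatic substituent for another that left the number unchanged within the scatter. Among the compounds with values here, the present change is larger, bringing a new ring substituent with a nitrile and a hydrogen-bond acceptor where none stood, and no measured pair covers such an exchange. The expectation therefore rests on the flatness seen so far: the step from compound 2 to compound 4 is expected to be a 1.3-fold higher number from compound 2 to compound 4 (0.10 log units; within the scatter), that is, no change beyond the scatter, with a wide range to allow for the unmeasured group. Compound 4 is expected to give 12 nM in this assay, between 4 nM and 40 nM.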

Compound 4, half-maximal effective concentration: 20 nM
Compound 4: the middle estimate sits 1.7-fold (0.22 log units) below what was measured, and the stated range covers the measured number.
By their numbers in this assay, from the lowest: compounds 1, 2 and 3 (each within the scatter of the next); then compound 4.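

In this assay, going by these compounds alone, the 3-cyanophenyl group gives the first step at this position that lies beyond the scatter: a 2.1-fold higher number from compound 2 to compound 4 (0.32 log units; beyond the scatter) and a 2.2-fold higher number from compound 1 to compound 4 (0.33 log units; beyond the scatter), both modest in size. The position therefore does not treat every aromatic group alike, as the near-identical numbers of compound 1 and compound 2 alone might have suggested, although the 3-cyanophenyl compound 4 still gives 20 nM, so the exchange shifts the number only modestly. The exchange alters both the substituent and its printed ring location, and nothing shown assigns the step to either one; no measurement among the data bears on why the number moved.

Still open, on these data alone, is whether the step follows the nitrile or its location on the ring, a question that 2-cyanophenyl and 3-fluorophenyl would each address at the same saturated chain carbon. Also open is how this position responds to a group of another kind on the ring, such as an amine or a carboxylic acid, since the aromatic groups shown carry only methyl, fluoro or nitrile substituents.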